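Replacing the group on the carbonyl carbon of compound 1

This account rests on a few compounds, and the source may have more. Where it says the series, first, only, none or still open, it means among the compounds named here.

Measured so far in a functional assay on HCT-116 cells (Homo sapiens) for antiproliferative activity, read by resazurin assay, with a stated time of 5 days; on this read-out higher numbers stand for weaker inhibition and lower numbers for stronger inhibition
compound 1 `Cc1ncoc1C(=O)NCc1ccc2cc(C(=O)NO)sc2c1F` gives 210 nM
compound 2 `Cc1cc(C(=O)NCc2ccc3cc(C(=O)NO)sc3c2F)oc1C` gives 470 nM
compound 3 `COc1ccccc1C(=O)NCc1ccc2cc(C(=O)NO)sc2c1F` gives 1200 nM

Compound 1 has the lowest number of the three, so it is the strongest inhibitor here. Compound 4 `CN(C)c1ccc(C(=O)NCc2ccc3cc(C(=O)NO)sc3c2F)cc1` keeps the core of compound 1 but has 4-(dimethylamino)phenyl in place of 4-methyl-1,3-oxazol-5-yl on a carbonyl carbon. The nearest guide is the swap to 2-methoxyphenyl, also a six-membered aromatic ring of carbon only, which gave a 5.7-fold higher number from compound 1 to compound 3 (0.76 log units; beyond the scatter). The swap to 4,5-dimethylfuran-2-yl gave a 2.2-fold higher number from compound 1 to compound 2 (0.35 log units; beyond the scatter). Among the measured compounds shown here, both raised the number, so a modest upward step is expected in this assay, although no measured compound carries this exact group. The expected step is a 3.8-fold higher number from compound 1 to compound 4 (0.58 log units; beyond the scatter). Compound 4 is estimated at 800 nM, within an expected range of 300 nM to 2200 nM.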

Compound 4, half-maximal inhibitory concentration: 60 nM
Beside the measured number, compound 4's estimate is 13-fold (1.12 log units) above it, outside the stated range (below it).
By their numbers in this assay, from the lowest: compound 4; then compound 1; then compound 2; then compound 3.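

In this assay, 4-(dimethylamino)phenyl on the carbonyl carbon gives a 3.5-fold lower number from compound 1 to compound 4 (0.54 log units; beyond the scatter), so a six-membered aromatic ring of carbon only need not raise the number here, as 2-methoxyphenyl did. The other two changes to this group give a 7.8-fold lower number from compound 2 to compound 4 (0.89 log units; beyond the scatter) and a 20-fold lower number from compound 3 to compound 4 (1.30 log units; beyond the scatter), so which ring is present, and what it carries, matters greatly at this position. Nothing measured here explains why the number fell. Still open, as far as these compounds go, is whether the fall belongs to the dimethylamino group or to the ring itself, a question that a plain phenyl group or a 4-aminophenyl group would help to separate.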